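A few compounds are considered here, and "the series" means these few. Any claim that something is new, unique, unknown or untested is made for them only; others in the source may bear on it.

In a functional assay for agonist activity at G protein-coupled receptor 88 (Homo sapiens), read by HTRF and cAMP accumulation (a higher number here means that more compound is needed for the effect, a lower number that less compound is needed), compound 3, `CC[C@H](C)[C@H](N)CN(C(=O)[C@@H]1C[C@H]1c1cccc(OC)c1)c1ccc(-c2ccccc2)cc1`, gives 3000 nM. That is the highest of the two single numbers recorded here. The nearest is compound 2, `O=C([C@@H]1C[C@H]1c1ccccc1)N(CCNCC1CCCC1)c1ccc(-c2ccccc2)cc1`, which in this assay gives 2.5 nM, a far lower number, well beyond the usual scatter. Compound 1, `CC[C@H](C)[C@H](N)CN(C(=O)[C@@H]1C[C@H]1c1ccccc1)c1ccc(-c2ccccc2)cc1`, has two entries rather than a single number; in this assay compound 1 gives 230 nM; 800 nM (2 entries), as shown by the several entries of compound 1 in this assay, 230 nM; 800 nM (2 entries).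

Compound 4, `CC[C@H](C)[C@H](N)CN(C(=O)[C@@H]1C[C@H]1c1ccc(C#N)cc1)c1ccc(-c2ccccc2)cc1`, differs from compound 3 in one place: 4-cyanophenyl in place of 3-methoxyphenyl on a saturated ring carbon. The rest of the structure stays as it is. For the measured compounds named here, no pair of measured compounds differs by this change alone, so there is no measured step to lean on. Compound 3 already stands well apart from compound 2 in this assay, and the exchange of one substituted phenyl for another on the saturated ring carbon gives no ground to expect a move beyond the scatter in either direction. Compound 4 is therefore expected to come out at an estimated 2500 nM, with a range from 600 nM to 10000 nM. The step that this estimate means, a 1.2-fold lower number from compound 3 to compound 4 (0.08 log units; within the scatter), is expected to lie within the scatter.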

Compound 4, half-maximal effective concentration: > 25000 nM
Compound 4 gave a limit, no number; the forecaster's own chance of this, stated with the estimate: 10%; middle value at least 10-fold (1.00 log units) away from the limit.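

In this assay compound 4 gives > 25000 nM, which is a limit of the assay and not a number: the limit of > 25000 nM in this assay, at which 1 of the 4 values shown sits.

This provides the first readable step across a single change among the compounds shown, an at least 8.3-fold higher number from compound 3 to compound 4 (0.92 log units; beyond the scatter), so the substituted phenyl on this saturated ring carbon of the three-membered ring cannot be exchanged freely in this series. The earlier compounds could not show this, and compound 1, with an unsubstituted phenyl at that place, offers several entries rather than a single number: the several entries of compound 1 in this assay, 230 nM; 800 nM (2 entries)

The change from 3-methoxyphenyl to 4-cyanophenyl replaces the substituent and moves it on the phenyl ring at once, so the compounds shown do not separate the nitrile itself from its place on the ring, and the full size of the step stays unknown. They also leave open how an amine, a carboxylic acid or a fluorine on that phenyl ring would read in this assay, and whether the cyclopentylmethyl amine chain of compound 2 would alter the outcome with either substituted phenyl.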